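Polyamine in place of a short ether chain on compound 3

The compounds below may be only part of what the source reports. "The series", "measured", "known", "first", "only" and "open" are said of these compounds alone.

Measured compounds:
compound 1, `CCCCCCCCCCCCCCCC(=O)OC[C@H](CSC[C@H](N)C(=O)NCC(=O)OC(C)C)OC(=O)CCCCCCCCCCCCCCC`, 0.45 nM
compound 2, `CCCCCCCCCCCC(=O)OC[C@H](CSC[C@H](N)C(=O)N[C@@H](CO)C(=O)O)OC(=O)CCCCCCCCCCC`, 6.48 nM
compound 3, `CCCCCCCCCCCCCCCC(=O)O[C@H](COC(=O)CNCCCOCCOCCOCC)CSC[C@H](N)C(=O)N[C@@H](CO)C(=O)O`, 2.11 nM

In a functional assay on HEK293 cells for agonist activity at Toll-like receptor 2 (Homo sapiens), read by spectrophotometry, with a stated time of 12 h (a higher number here means that more compound is needed for the effect, a lower number that less compound is needed), compound 1 gives 0.45 nM, compound 2 gives 6.48 nM and compound 3 gives 2.11 nM. Among these three numbers compound 3 stands second highest: it lies nearest to compound 2, whose number is higher, and furthest from compound 1, whose number is lower, and both gaps are beyond the usual scatter of this assay.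

Compound 4, `CCCCCCCCCCCCCCCC(=O)O[C@H](COC(=O)CNCCCNCCCCNCCCN)CSC[C@H](N)C(=O)N[C@@H](CO)C(=O)O`, has not been measured. It differs from compound 3 in one place: (4-((3-aminopropyl)amino)butyl)amino in place of 2-(2-ethoxyethoxy)ethoxy on a saturated chain carbon, three bonds along the chain from an amine nitrogen. No pair of measured compounds shows this kind of exchange, so the size of the step has no direct precedent among the compounds shown. The shared core of compound 3 and compound 4, with its two lipid chains and the cysteinyl-serine portion, stays the same. The estimate is that the step from compound 3 to compound 4 in this assay stays within the scatter, a 1.1-fold lower number from compound 3 to compound 4 (0.02 log units; within the scatter). For compound 4 the expected value is 2 nM, with a range from 0.5 nM to 8 nM.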

Compound 4, half-maximal effective concentration: 3.23 nM
For compound 4 the middle estimate is 1.6-fold (0.21 log units) below the measured one; low and high end bracket the measured number.
By their numbers in this assay, from the lowest: compound 1; then compounds 3, 4 and 2 (each within the scatter of the next, the first and the last beyond it).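

In this assay, (4-((3-aminopropyl)amino)butyl)amino in place of 2-(2-ethoxyethoxy)ethoxy on a saturated chain carbon, three bonds along the chain from an amine nitrogen, gives a 1.5-fold higher number from compound 3 to compound 4 (0.18 log units; within the scatter). The earlier compounds shown here held no exchange at this position, and this step shows that it accepts a chain carrying amine nitrogens and hydrogen-bond donors as well as the ether chain, which has oxygens and no donors, with the two numbers within the scatter of each other. Nothing at hand explains this outcome.

From the compounds shown here alone, it remains open whether a plain hexyl chain, a terminal carboxylic acid or a longer polyamine would fare the same at this position. Going by these compounds, it is also open whether the polyamine would be accepted as well on the core of compound 1 or compound 2.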